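Nitro for Nitrile on a Sulfonyl Arm

This account rests on a few compounds, and the source may have more. Where it says the series, first, only, none or still open, it means among the compounds named here.

Measured so far:
compound 1 `C=C(C)C(=O)N1N=C(c2ccc(-n3ccnc3)cc2)CC1c1ccc(N(C)C)cc1` 1.6%
compound 2 `CN(C)c1ccc(C2CC(c3ccc(-n4ccnc4)cc3)=NN2S(=O)(=O)c2ccc(C#N)cc2)cc1` 4.7%

In a functional assay on HCC1806 cells (Homo sapiens) for inhibition, read by sulforhodamine B assay, tested at 10 uM (on this read-out lower numbers stand for less inhibition and higher numbers for more inhibition at the one concentration tested (going by the name of the read-out)), compound 2 gives 4.7%, the higher of the two numbers, with compound 1 nearest at 1.6%, a step of a number 3.1 percentage points higher from compound 1 to compound 2 (within the scatter). Compound 3 `CN(C)c1ccc(C2CC(c3ccc(-n4ccnc4)cc3)=NN2S(=O)(=O)c2ccc([N+](=O)[O-])cc2)cc1` differs from compound 2 by nitro in place of cyano on an aromatic carbon. Among the compounds with values here, the one measured step, a number 3.1 percentage points higher from compound 1 to compound 2 (within the scatter), concerns the group on the ring nitrogen, not the substituent on the outer ring, so no measured step bears on this change, and both measured values sit near zero. A step of no size beyond the scatter is therefore expected, namely a number 0.3 percentage points higher from compound 2 to compound 3 (within the scatter). For compound 3 the estimated value is 5%, expected between -5% and 15%.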

Compound 3, a percentage reported as inhibition, at one concentration (the size of the read-out at that concentration, not a potency): 46.6%
Beside the measured number, compound 3's estimate is 41.6 percentage points below it, and the stated range ends below it.
By their numbers in this assay, from the lowest: compounds 1 and 2 (each within the scatter of the next); then compound 3.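

The substituent on the outer ring of the sulfonyl arm can decide this result: nitro in place of cyano gives a number 41.9 percentage points higher from compound 2 to compound 3 (beyond the scatter) in this assay. Changing the whole group on the ring nitrogen to (4-nitrophenyl)sulfonyl gives a number 45 percentage points higher from compound 1 to compound 3 (beyond the scatter) and so also lifts the number clear of the scatter. Nothing available explains why nitro and cyano differ here. As far as these compounds go, whether nitro alone does this remains open. An amine or a carboxylic acid on the same aromatic carbon would help to show how particular the nitro result is.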